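The compounds below may be only part of what the source reports. "The series", "measured", "known", "first", "only" and "open" are said of these compounds alone.

Measured compounds:
compound 1 `CN(C(=O)NC(=O)c1ccccc1F)c1nc(C(F)(F)F)c(C(=O)N/N=C/c2ccccc2C(F)(F)F)s1` — 10.1 ug/mL
compound 2 `CN(C(=O)NC(=O)c1cccc(C(F)(F)F)c1)c1nc(C(F)(F)F)c(C(=O)N/N=C/c2ccccc2C(F)(F)F)s1` — 7.37 ug/mL
compound 3 `CN(C(=O)NC(=O)c1cccc([N+](=O)[O-])c1)c1nc(C(F)(F)F)c(C(=O)N/N=C/c2ccccc2C(F)(F)F)s1` — 4.15 ug/mL

In a functional assay on HeLa cells (Homo sapiens) for inhibition, read by MTT assay, with a stated time of 72 h (on this read-out higher numbers stand for weaker inhibition and lower numbers for stronger inhibition), compound 1 gives the highest of the three numbers. Its neighbours differ only in the aryl group on the carbonyl: a 1.4-fold lower number from compound 1 to compound 2 (0.14 log units; within the scatter), and a 2.4-fold lower number from compound 1 to compound 3 (0.39 log units; beyond the scatter). Compound 4 `CNc1nc(C(F)(F)F)c(C(=O)N/N=C/c2ccccc2C(F)(F)F)s1` is not yet measured; it differs from compound 1 by hydrogen in place of ((2-fluorophenyl)carbonyl)carbamoyl on a nitrogen on an aromatic ring. Going by the values given here, no measured step touches this change: all three measured compounds keep the whole ((2-fluorophenyl)carbonyl)carbamoyl group and vary only its ring. Among the compounds with values here, the data therefore give no direction for this step, and the range must be wide. The estimate for compound 4 is 18 ug/mL (range 4 ug/mL to 70 ug/mL), which is expected to be a 1.8-fold higher number from compound 1 to compound 4 (0.25 log units; within the scatter).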

Compound 4, half-maximal inhibitory concentration: > 100 ug/mL
Compound 4 ended at the assay's limit; the forecaster's own chance of this, stated with the estimate: 20%; at least 5.5-fold (0.74 log units) between middle value and limit.
By their numbers in this assay, from the lowest: compounds 3, 2 and 1 (each within the scatter of the next, the first and the last beyond it). At a limit, above all of these: compound 4.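

Compound 4 gives a limit of the assay, not a number: the limit of > 100 ug/mL in this assay, at which 1 of the 4 values shown sits. Replacing the whole ((2-fluorophenyl)carbonyl)carbamoyl on this nitrogen with hydrogen gives an at least 9.9-fold higher number from compound 1 to compound 4 (0.99 log units; beyond the scatter). The earlier compounds varied only the ring of that group, and their largest step was a 2.4-fold lower number from compound 1 to compound 3 (0.39 log units; beyond the scatter), so among these four compounds, losing the whole group weighs more than any change to its ring.

The compounds shown leave open which part of the group is needed. An acetyl or a plain carbamoyl on this nitrogen could separate the urea portion from the aryl ring.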